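Losing the Chloro on the Pendant Phenyl

This account rests on a few compounds, and the source may have more. Where it says the series, first, only, none or still open, it means among the compounds named here.

Measured compounds:
compound 1, `Cc1cc(O)c(C(=O)/C=C/c2ccccc2Cl)c(-c2ccc(Cl)cc2)c1C(=O)/C=C/c1ccccc1Cl`, 29000 nM
compound 2, `COc1ccc(/C=C/C(=O)c2c(C)cc(O)c(C(=O)/C=C/c3ccc(OC)cc3)c2-c2ccc(OCc3ccccc3)cc2)cc1`, 12000 nM
compound 3, `Cc1cc(O)c(C(=O)/C=C/c2ccc(Cl)cc2)c(-c2ccc(Cl)cc2)c1C(=O)/C=C/c1ccc(Cl)cc1`, 30000 nM

In a functional assay on MDA-MB-231 cells (Homo sapiens) for cytotoxicity, read by MTT assay, with a stated time of 24 h (on this read-out higher numbers stand for weaker inhibition and lower numbers for stronger inhibition), compound 3 gives 30000 nM, the highest of the three numbers. Compound 1 gives 29000 nM, and the two values lie within the scatter of each other, so no order between compound 1 and compound 3 can be read. Compound 2 gives 12000 nM, and its gap to compound 3 lies beyond the scatter.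

Compound 4, `Cc1cc(O)c(C(=O)/C=C/c2ccc(Cl)cc2)c(-c2ccccc2)c1C(=O)/C=C/c1ccc(Cl)cc1`, differs from compound 3 in one place: hydrogen in place of chloro on an aromatic carbon. For the measured compounds named here, no measured pair shows this change, so its effect is not known from these data. Because compound 1 at 29000 nM lies within the scatter of compound 3 although its chloro pattern differs, a step of similar smallness is expected here. Compound 4 is expected to give 35000 nM, with a range from 15000 nM to 80000 nM. The estimated step of a 1.2-fold higher number from compound 3 to compound 4 (0.07 log units; within the scatter) is expected to stay within the scatter, in neither direction beyond it.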

Compound 4, half-maximal inhibitory concentration: 7900 nM
Compound 4: middle estimate off by 4.4-fold (0.65 log units), on the high side; measured number outside the range, below it.
By their numbers in this assay, from the lowest: compounds 4 and 2 (each within the scatter of the next); then compounds 1 and 3 (each within the scatter of the next).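

The change from 4-chlorophenyl to phenyl, hydrogen in place of chloro on an aromatic carbon para to a large group, gives a 3.8-fold lower number from compound 3 to compound 4 (0.58 log units; beyond the scatter) in this assay and shows that the read-out responds to what this position carries. For the compounds shown here, this is the first pair that differs in one place, and it shows that the chloro is not needed here for the lower number: the compound without it is the stronger of the two. No measurement shown accounts for this step.

From the compounds shown here alone, it remains open how this position would read with an amine or a carboxylic acid in place of the hydrogen. Going by these compounds, it is also open whether losing this chloro gives a step of similar size when the rest of the molecule carries the chloro pattern of compound 1.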